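Aryl Ketone Variation in a Cytotoxic Series

A few compounds are considered here, and "the series" means these few. Any claim that something is new, unique, unknown or untested is made for them only; others in the source may bear on it.

Compound 1 `O=C(/C=C/c1ccc2c(c1)B(O)OC2)c1ccccc1` — 3400 nM
Compound 2 `O=C(/C=C/c1ccc2c(c1)B(O)OC2)c1ccc(-c2ccccc2)cc1` — 4900 nM
Compound 3 `O=C(/C=C/c1ccc2c(c1)B(O)OC2)c1cccs1` — 10400 nM

In a functional assay on SK-OV-3 cells (Homo sapiens) for cytotoxicity, read by MTT assay, with a stated time of 48 h (on this read-out higher numbers stand for weaker inhibition and lower numbers for stronger inhibition), compound 1 holds the lowest of the three numbers. Compound 2 lies nearest, a 1.4-fold higher number from compound 1 to compound 2 (0.16 log units; within the scatter). Compound 3 lies furthest, a 3.1-fold higher number from compound 1 to compound 3 (0.49 log units; beyond the scatter).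

Compound 4 `O=C(/C=C/c1ccc2c(c1)B(O)OC2)c1cccnc1` differs from compound 1 in one place: pyridin-3-yl in place of phenyl on a carbonyl carbon. For the measured compounds named here, no measured step exchanges one six-membered ring for another at this carbonyl carbon. The closest guide is the step at the same position, a 3.1-fold higher number from compound 1 to compound 3 (0.49 log units; beyond the scatter), a modest rise in the number; the step of a 1.4-fold higher number from compound 1 to compound 2 (0.16 log units; within the scatter) changes the ring elsewhere and stays within the scatter. A small rise in the number, possibly within the scatter, is therefore expected. The expected step is a 1.5-fold higher number from compound 1 to compound 4 (0.17 log units; within the scatter). Compound 4 is estimated at 5000 nM, with a range from 2500 nM to 12000 nM.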

Compound 4, half-maximal inhibitory concentration: 18500 nM
Beside the measured number, compound 4's estimate is 3.7-fold (0.57 log units) below it; measured number above the stated range.
By their numbers in this assay, from the lowest: compounds 1 and 2 (each within the scatter of the next); then compounds 3 and 4 (each within the scatter of the next).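

For the compounds shown here, at the carbonyl carbon, keeping a six-membered aromatic ring does not keep the number: pyridin-3-yl gives a 5.4-fold higher number from compound 1 to compound 4 (0.74 log units; beyond the scatter) in this assay and so moves it further than the earlier compounds could have suggested. The rise seen with thiophen-2-yl is therefore not confined to a change of ring size, and a 1.8-fold higher number from compound 3 to compound 4 (0.25 log units; within the scatter) leaves these two rings level in this series. Going by these compounds, whether an amine or a methoxy group on the phenyl ring of compound 1 would hold its number stays open, as does the outcome for pyridin-4-yl at the same carbon. Nothing measured here bears on why the number moves.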